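This account rests on a few compounds, and the source may have more. Where it says the series, first, only, none or still open, it means among the compounds named here.

Of the compounds shown here, three have been tested in a functional assay on UACC-62 cells (Homo sapiens) for antiproliferative activity, read by sulforhodamine B assay, with a stated time of 48 h; a lower number here means a stronger inhibitor, a higher number a weaker inhibitor. Compound 1 `Nc1cccc2c(-c3cccc(NC(=O)c4ccc5c(c4)OCCO5)c3)ccnc12` gives 110 nM in this assay. Compound 2 `CC(=O)Nc1cccc2c(-c3cccc(NC(=O)c4ccc5c(c4)OCCO5)c3)ccnc12` differs from compound 1 by acetyl in place of hydrogen on a nitrogen on an aromatic ring; in this assay compound 2 gives 68 nM, so the step is a 1.6-fold lower number from compound 1 to compound 2 (0.21 log units; within the scatter). Compound 3 `Nc1cccc2c(-c3cccc(NC(=O)Nc4cc(C(F)(F)F)cc(C(F)(F)F)c4)c3)ccnc12` carries a different group on the shared core; how its core differs from that of compound 1 is not broken down here. In this assay compound 3 gives 1800 nM, the highest number of the three, and both of the other two sit well beyond the usual scatter from it.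

Compound 4 `CC(=O)Nc1cccc2c(-c3cccc(NC(=O)Nc4cc(C(F)(F)F)cc(C(F)(F)F)c4)c3)ccnc12` has not been measured. It differs from compound 3 by acetyl in place of hydrogen on a nitrogen on an aromatic ring, the same change, at the same place on the aromatic ring nitrogen, that separates compound 2 from compound 1. Because the earlier step was a 1.6-fold lower number from compound 1 to compound 2 (0.21 log units; within the scatter), a step of similar size is expected here: a 1.5-fold lower number from compound 3 to compound 4 (0.18 log units; within the scatter). Compound 4 is therefore estimated at 1200 nM, with a likely range from 500 nM to 3000 nM.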

Compound 4, half-maximal inhibitory concentration: 10600 nM
Estimate against measurement, compound 4: 8.8-fold (0.95 log units) below; the whole stated range lies below it.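

In this assay, placing acetyl on the nitrogen of compound 3 gives a 5.9-fold higher number from compound 3 to compound 4 (0.77 log units; beyond the scatter), so on this core the change from amino to acetamido produces a weaker inhibitor. Set beside the earlier step, the same change does not carry over unchanged from one core to the other: the same change on two cores in this assay, a 1.6-fold lower number (0.21 log units; within the scatter) from compound 1 to compound 2 and a 5.9-fold higher number (0.77 log units; beyond the scatter) from compound 3 to compound 4, 9.5-fold (0.98 log units) apart, beyond the scatter of two such steps. This shows that, for these two pairs, the result of the change depends on the core that carries it, but two pairs cannot show which part of the cores is responsible or predict the result on a further core.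

The compounds shown leave open whether a different group on this nitrogen, such as a methyl group or a longer propanoyl chain, would also give different results on the two cores. They also leave open how the acetyl change would behave if one trifluoromethyl group of compound 3 were replaced by a chlorine atom.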